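The source may report more compounds than this note shows. Statements on the series, on what has been measured and on what is new or still open speak of the compounds shown alone.

Three compounds share one core and differ only in the aromatic group carried on an oxygen on an aromatic ring. Compound 1 `Cc1nn(C)c(Oc2ccccc2F)c1/C=N\CCCCCCOc1cc2oc(=O)cc(C)c2cc1Cl` carries a 2-fluorophenyl there, compound 2 `Cc1nn(C)c(Oc2ccc(F)cc2)c1/C=N\CCCCCCOc1cc2oc(=O)cc(C)c2cc1Cl` a 4-fluorophenyl and compound 3 `Cc1nn(C)c(Oc2cccc(Br)c2)c1/C=N\CCCCCCOc1cc2oc(=O)cc(C)c2cc1Cl` a 3-bromophenyl. In a functional assay on SMMC-7721 cells (Homo sapiens) for antiproliferative activity, read by MTT assay, with a stated time of 72 h (a lower number here means a stronger inhibitor, a higher number a weaker inhibitor), compound 1 reaches only a limit of the assay, > 25000 nM. In this assay compound 2 gives 13500 nM and compound 3 gives 5080 nM. The steps between them are an at least 1.8-fold lower number from compound 1 to compound 2 (0.26 log units; that floor lies within the scatter), an at least 4.9-fold lower number from compound 1 to compound 3 (0.69 log units; beyond the scatter) and a 2.7-fold lower number from compound 2 to compound 3 (0.42 log units; beyond the scatter). Among the two plain numbers compound 3 therefore stands lowest, with compound 2 nearest to it. Compound 4 `Cc1ccc(Oc2c(/C=N\CCCCCCOc3cc4oc(=O)cc(C)c4cc3Cl)c(C)nn2C)cc1` continues the same kind of exchange: 4-methylphenyl in place of 3-bromophenyl on an oxygen on an aromatic ring. All three measured steps swap this one aromatic group, and each moved the number by a modest amount at most, so a step of similar size is expected here; which direction an exchange of a bromine-bearing ring for a methyl-bearing ring takes is not shown by the measured pairs, and a small loss is taken as the middle case. The step from compound 3 to compound 4 is expected to be a 1.6-fold higher number from compound 3 to compound 4 (0.20 log units; within the scatter). For compound 4 a value of 8000 nM is estimated, within 3000 nM to 25000 nM.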

Compound 4, half-maximal inhibitory concentration: 18600 nM
The estimate for compound 4 lay 2.3-fold (0.37 log units) below the measured number, and the stated range covers the measured number.
By their numbers in this assay, from the lowest: compound 3; then compounds 2 and 4 (each within the scatter of the next). At a limit, above all of these: compound 1.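

In this assay, 4-methylphenyl in place of 3-bromophenyl gives a 3.7-fold higher number from compound 3 to compound 4 (0.56 log units; beyond the scatter), so replacing the 3-bromophenyl with this methyl-bearing ring does not preserve the lowest number, and compound 3 stays clear of the other measured compounds. Methyl in place of fluoro on an aromatic carbon gives a 1.4-fold higher number from compound 2 to compound 4 (0.14 log units; within the scatter), a step too small to separate the two compounds, so this exchange on the ring shows no measurable effect. Compound 1 stands at a limit of the assay, which makes its step only a floor, an at least 1.3-fold lower number from compound 1 to compound 4 (0.12 log units; that floor lies within the scatter), and that step cannot rank the two compounds: the limit of > 25000 nM in this assay, at which 1 of the 4 values shown sits.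

The compounds shown do not separate the identity of the group on the ring from where it sits, and a 4-bromophenyl and a 3-methylphenyl would be the direct tests of that question. Also open, from the compounds shown here alone, is how a phenyl ring carrying an amine or a carboxylic acid would behave on this oxygen in this assay.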